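The source may hold more compounds than are shown below. What is called first, only, known or untested is meant among the compounds shown, and "the series" means these compounds.

Measured in a functional assay on DLD-1 cells (Homo sapiens) for cytotoxicity, read by colorimetric assay and MTT assay, with a stated time of 3 days, tested at 20 uM; a lower number here means a stronger effect, a higher number a weaker effect of the compound at the concentration tested:

- compound 1 `COc1ccc(-n2cc(-c3ccccc3)c(-c3ccc4c(c3)NC(=O)CO4)n2)cc1` gives 35.6%
- compound 2 `O=C1COc2ccc(-c3[nH]c(-c4c[nH]c5ncccc45)nc3-c3ccccc3)cc2N1` gives 53.5%
- compound 3 `O=C1COc2ccc(-c3nn(-c4ccccc4)cc3-c3ccccc3)cc2N1` gives 47.7%

Compound 2 holds the highest of the three numbers; its gap to compound 3 lies within the scatter, its gap to compound 1 beyond it. For the measured compounds named here, the one measured step, a number 12.1 percentage points higher from compound 1 to compound 3 (beyond the scatter), concerns a change on a different part of the molecule and does not bear on the step at hand.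

Compound 4 `O=C1COc2ccc(-c3[nH]c(-c4ccc(F)cc4)nc3-c3ccccc3)cc2N1` differs from compound 2 in this way: a group of 7 heavy atoms (6 carbon, 1 fluorine; one six-membered aromatic ring of carbon only) in place of a group of 9 heavy atoms (7 carbon, 2 nitrogen; one five-membered aromatic ring with 1 hetero atom, one six-membered aromatic ring with 1 hetero atom), on an aromatic carbon. Going by the values given here, no measured step speaks to this exchange, so the estimate rests on compound 2 alone and carries a broad range. Compound 4 is expected to give 48% (range 28% to 68%). The expected step of a number 5.5 percentage points lower from compound 2 to compound 4 (within the scatter) is therefore estimated to stay within the scatter.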

Compound 4, a percentage reported as activity, at one concentration (the size of the read-out at that concentration, not a potency): 29.5%
Beside the measured number, compound 4's estimate is 18.5 percentage points above it; the range from low to high includes it.
By their numbers in this assay, from the lowest: compounds 4 and 1 (each within the scatter of the next); then compounds 3 and 2 (each within the scatter of the next).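

In this assay, 4-fluorophenyl on the aromatic carbon between two ring nitrogen atoms, in place of the larger two-ring group, gives a number 24 percentage points lower from compound 2 to compound 4 (beyond the scatter), so the group at this position can shift the read-out. The exchange changes the ring count, hetero atoms and hydrogen-bond donors together, so the step cannot be assigned to any one of them. Nothing at hand explains its size.

On these data alone, whether the fluorine matters remains open, as a plain phenyl group at this carbon would show. A morpholine or an amine there would test whether an aromatic ring is needed at all.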